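A Shorter Chain on a Compound Held at a Limit

This account rests on a few compounds, and the source may have more. Where it says the series, first, only, none or still open, it means among the compounds named here.

Measured in a functional assay on the whole organism with Mus musculus as the target; on this read-out lower numbers stand for an effect already at smaller amounts and higher numbers for an effect only at larger amounts of compound:
- Compound 1 `CCCn1c(-c2ccc(Cl)cc2)nn(C)c1=S`: > 12.5 mg/kg
- Compound 2 `Cn1nc(-c2ccc(F)cc2F)n(C)c1=S`: 1 mg/kg

Going by the values given here, only two compounds have been measured so far, and no single-place step connects them. Compound 1 stands at a limit and has no exact number: > 12.5 mg/kg. This is the limit of > 12.5 mg/kg in this assay, at which 1 of the 2 values shown sits. Compound 2 has a true number, 1 mg/kg, so a dose in this assay can be read for a compound of this kind.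

The next compound, compound 3 `CCn1c(-c2ccc(Cl)cc2)nn(C)c1=S`, has not yet been measured. It has hydrogen in place of methyl on a saturated chain carbon, two bonds along the chain from an aromatic nitrogen, so the propyl of compound 1 becomes ethyl. Among the compounds with values here, with no measured step to draw on, the expectation is a moderate shift towards smaller doses, and its size is uncertain since compound 1 gives only a limit. The expected change is an at least 2.0-fold lower number from compound 1 to compound 3 (0.31 log units; beyond the scatter). Compound 3 is estimated at 6 mg/kg, with an expected range of 2 mg/kg to 20 mg/kg.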

Compound 3, dose for half-maximal effect: > 50 mg/kg
Compound 3 was reported as a limit; the forecaster's own chance of this, stated with the estimate: 30%; middle value at least 8.3-fold (0.92 log units) away from the limit.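

In this assay compound 3 gives > 50 mg/kg, which is a limit and not a number. Compound 1 likewise stands at a limit, > 12.5 mg/kg, so no step can be read between compound 1 and compound 3. The compounds shown leave open what true dose either compound has in this assay, and whether going from propyl to ethyl changes it at all.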